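The compounds below may be only part of what the source reports. "The series", "measured", "known", "first", "only" and "open" are said of these compounds alone.

Measured so far:
compound 1, `CC(C(=O)NCc1ccc(C(F)(F)F)nc1NCc1ccccc1)c1ccc(NS(C)(=O)=O)c(F)c1`: 203 nM
compound 2, `CC(C(=O)NCc1ccc(C(F)(F)F)nc1N(C)C)c1ccc(NS(C)(=O)=O)c(F)c1`: 2390 nM

Going by the values given here, in a functional assay on CHO-K1 cells for antagonist activity at transient receptor potential cation channel subfamily V member 1 (Homo sapiens), read by FLIPR (on this read-out higher numbers stand for weaker inhibition and lower numbers for stronger inhibition), compound 1 holds the lower of these two numbers, and the only recorded step, a 12-fold higher number from compound 1 to compound 2 (1.07 log units; beyond the scatter), is the one that bears on what follows. Compound 3, `COC1CCN(c2nc(C(F)(F)F)ccc2CNC(=O)C(C)c2ccc(NS(C)(=O)=O)c(F)c2)CC1`, has not yet been measured. It differs from compound 1 by 4-methoxypiperidin-1-yl in place of benzylamino on an aromatic carbon. As in that recorded step, the benzylamino and its aromatic ring leave, so a weakening of inhibition beyond the scatter is expected, though perhaps not as large: a 3.9-fold higher number from compound 1 to compound 3 (0.60 log units; beyond the scatter). Compound 3 is therefore estimated at 800 nM, with a range from 250 nM to 2500 nM.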

Compound 3, half-maximal inhibitory concentration: 280 nM
For compound 3 the middle estimate is 2.9-fold (0.46 log units) above the measured one; the measured number falls inside the stated range.
By their numbers in this assay, from the lowest: compounds 1 and 3 (each within the scatter of the next); then compound 2.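

In this assay the aromatic ring of benzylamino can leave this position without a loss beyond the scatter, with a 1.4-fold higher number from compound 1 to compound 3 (0.14 log units; within the scatter) when 4-methoxypiperidin-1-yl enters. Replacing dimethylamino with the same group gives an 8.5-fold lower number from compound 2 to compound 3 (0.93 log units; beyond the scatter) on this carbon, so the weaker inhibition of compound 2 does not extend to every group lacking that aromatic ring. No measured evidence accounts for this difference. On these data alone, whether the methoxy group contributes stays open, and plain piperidin-1-yl or morpholin-4-yl on the same carbon would address that.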